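Adding a methoxy group to compound 1

This account rests on a few compounds, and the source may have more. Where it says the series, first, only, none or still open, it means among the compounds named here.

- compound 1 `CC1(/C=C/c2ccccc2)C=CC(=O)O1` gives 86900 nM
- compound 2 `COc1cccc(/C=C/C2(C)C=CC(=O)O2)c1` gives 31600 nM

In a functional assay on PC-3 cells (Homo sapiens) for inhibition, read by sulforhodamine B assay, with a stated time of 48 h (on this read-out higher numbers stand for weaker inhibition of growth and lower numbers for stronger inhibition of growth), compound 1 has the higher of the two numbers, so it is the weaker growth inhibitor of the pair. Compound 3 `COc1ccc(/C=C/C2(C)C=CC(=O)O2)cc1` has not been measured and differs from compound 1 in one place: methoxy in place of hydrogen on an aromatic carbon. Methoxy takes the place of hydrogen on an aromatic carbon. Among the compounds with values here, the one step that bears on this is the same swap at a different aromatic carbon: a 2.8-fold lower number from compound 1 to compound 2 (0.44 log units; beyond the scatter). A single modest step is thin evidence, so a similar or smaller drop is expected in this assay. The expected step is a 2.2-fold lower number from compound 1 to compound 3 (0.34 log units; beyond the scatter). For compound 3 the estimated value is 40000 nM, with an expected range from 15000 nM to 90000 nM.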

Compound 3, concentration for total growth inhibition: 145000 nM
Estimate against measurement, compound 3: 3.6-fold (0.56 log units) below, and the stated range ends below it.
By their numbers in this assay, from the lowest: compound 2; then compounds 1 and 3 (each within the scatter of the next).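

With methoxy on the aromatic carbon para to a group of 9 heavy atoms, this assay shows a 1.7-fold higher number from compound 1 to compound 3 (0.22 log units; within the scatter), so at this position compound 3 cannot be told apart from compound 1. The other aromatic carbon gave a 2.8-fold lower number from compound 1 to compound 2 (0.44 log units; beyond the scatter), which is beyond the scatter, so the same swap does not give the same result at every aromatic carbon. Nothing available explains this difference between the two positions.

Still open, from the compounds shown here alone, is whether a different group at this para position, such as an amine or a carboxylic acid, would shift the number. Whether a longer chain on the oxygen in place of methoxy would do so is also unknown.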